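A few compounds are considered here, and "the series" means these few. Any claim that something is new, unique, unknown or untested is made for them only; others in the source may bear on it.

Compounds measured in a functional assay on L5178Y cells (Mus musculus); a lower number here means a less potent compound, a higher number a more potent compound, by a factor of ten per unit of this negative logarithm:
- compound 1 `CCCCCCCCCOc1cccc(N2C(N)=NC(N)=NC2(C)C)c1` gives 6.57
- compound 2 `CCCCCCCCCCCCOc1cccc(N2C(N)=NC(N)=NC2(C)C)c1` gives 6.24
- compound 3 `CC1(C)N=C(N)N=C(N)N1c1cccc(Br)c1` gives 5.9

Compound 3 stands lowest of the three in this assay, its number lying beyond the scatter under both compound 2 and compound 1. Compound 4 `CCCCOc1cccc(N2C(N)=NC(N)=NC2(C)C)c1` is not yet measured; it differs from compound 3 by butoxy in place of bromo on an aromatic carbon. Among the measured compounds shown here, no measured step covers this exchange directly. For the measured compounds named here, the only measured step, a number 0.33 log units lower from compound 1 to compound 2 (beyond the scatter), concerns chain length on an alkoxy group and is of modest size. Both alkoxy compounds sit above compound 3, so the exchange is expected to raise the number; the step of a number 0.40 log units higher from compound 3 to compound 4 (beyond the scatter) is estimated on that basis. Compound 4 is expected to give about 6.3, within a range of 5.7 to 6.9.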

Compound 4, logarithm of the reciprocal of the active concentration, log(1/C): 5.95
Estimate against measurement, compound 4: 0.35 log units above, and the stated range covers the measured number.
By their numbers in this assay, from the lowest: compounds 3, 4 and 2 (each within the scatter of the next, the first and the last beyond it); then compound 1.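

Exchanging bromo for butoxy on this aromatic carbon gives no separable change in this assay (a number 0.05 log units higher from compound 3 to compound 4 (within the scatter)). Alkoxy at this position is therefore not enough to lift the number, and chain length decides: compound 1 stands clear of the butoxy compound (a number 0.62 log units lower from compound 1 to compound 4 (beyond the scatter)), whereas compound 2 does not (a number 0.29 log units lower from compound 2 to compound 4 (within the scatter)). No evidence on the reason for these steps is available.

Going by these compounds, whether an amine or a carboxylic acid here would depart from bromo remains open. Also open, on these data alone, is how a hexyl chain would sit relative to the chain of compound 1.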